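Swapping the aryl group on a dibenzyl urea

The compounds below may be only part of what the source reports. "The series", "measured", "known", "first", "only" and "open" are said of these compounds alone.

Three ureas have been measured in an assay on isolated protein for inhibition of sterol O-acyltransferase 1 (Rattus norvegicus); a higher number here means a weaker inhibitor, a lower number a stronger inhibitor. Compound 1, `CCCCCCN(CCCCCC)C(=O)Nc1ccc(C)cc1C`, gives 0.11 ug/mL in this assay. Compound 2, `CCCCCCCN(CCCCCCC)C(=O)Nc1ccc(C)cc1C`, gives 0.26 ug/mL. Compound 3, `Cc1cc(C)c(NC(=O)N(Cc2ccccc2)Cc2ccccc2)cc1C`, gives 0.16 ug/mL. The value of compound 3 sits between the other two, and its gaps to compound 1 and to compound 2 both fall inside the usual scatter of repeated measurements, so the three compounds cannot be told apart on these numbers.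

Compound 4, `O=C(Nc1cc(Cl)cc(Cl)c1)N(Cc1ccccc1)Cc1ccccc1`, keeps the two benzyl groups of compound 3 on the urea nitrogen and changes only the other end: 3,5-dichlorophenyl in place of 2,4,5-trimethylphenyl on an amide-type nitrogen. For the measured compounds named here, no measured pair in this set isolates such a change, so its effect has to be guessed from how narrow the spread of the three measured values is. Since compounds 1, 2 and 3 differ in their carbon substituents yet stay within the scatter of one another, a change of this kind is expected to move this assay only modestly, if at all, with a slight lean toward a weaker inhibitor, meaning a step from compound 3 to compound 4 of about a 1.9-fold higher number from compound 3 to compound 4 (0.27 log units; within the scatter). Compound 4 is therefore estimated at 0.3 ug/mL, with a plausible range from 0.08 ug/mL to 1.2 ug/mL.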

Compound 4, half-maximal inhibitory concentration: 1.53 ug/mL
The estimate for compound 4 lay 5.1-fold (0.71 log units) below the measured number; measured number above the stated range.
By their numbers in this assay, from the lowest: compounds 1, 3 and 2 (each within the scatter of the next, the first and the last beyond it); then compound 4.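

With the two benzyl groups held fixed on the urea nitrogen, the aryl group on the amide-type nitrogen turns out to matter in this assay: 3,5-dichlorophenyl in place of 2,4,5-trimethylphenyl gives a 9.6-fold higher number from compound 3 to compound 4 (0.98 log units; beyond the scatter). For the compounds shown here, the earlier compounds could not show this, since no pair among compound 1, compound 2 and compound 3 differs in one place only, so this is the first single change that can be read, and it gives a weaker inhibitor. Nothing available explains why this swap weakens inhibition, so the result stands as a plain observation about these two aryl groups.

The swap removes three methyl groups and brings in two chlorines in one step, so these compounds cannot say whether losing the methyl groups, gaining the chlorines, or both accounts for the loss; a plain phenyl group or a methoxyphenyl group on the same nitrogen would help separate these possibilities. As far as these compounds go, it also remains open whether the same aryl swap would weaken inhibition to a similar extent on the core of compound 1, which carries alkyl chains instead of benzyl groups.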